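The source may hold more compounds than are shown below. What is called first, only, known or untested is meant among the compounds shown, and "the series" means these compounds.

Measured so far in a functional assay on cells for agonist activity at C-X-C chemokine receptor type 4 (Homo sapiens), read by fluorescence and calcium flux, with a stated time of 90 s; on this read-out lower numbers stand for an effect already at smaller amounts and higher numbers for an effect only at larger amounts of compound:
compound 1 `C(=C/CN(C[C@H]1Cc2ccccc2CN1)[C@H]1CCCc2cccnc21)\CNCC1CCOCC1`: > 30000 nM, a limit of the assay
compound 2 `FC1(F)CCC(NC/C=C/CN(C[C@H]2Cc3ccccc3CN2)[C@H]2CCCc3cccnc32)CC1`: > 30000 nM, a limit of the assay
compound 3 `C(=C/CN(C[C@H]1Cc2ccccc2CN1)[C@H]1CCCc2cccnc21)\CNC1CCOCC1`: > 30000 nM, a limit of the assay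

Compound 3 stands, like the other two members, only at a limit in this assay; no number is available for it. The three measured steps, a step that the two limits leave unreadable from compound 1 to compound 2, a step that the two limits leave unreadable from compound 1 to compound 3 and a step that the two limits leave unreadable from compound 2 to compound 3, all stay unreadable, each of them joining two limits. The only fixed point on the numbers is the limit of > 30000 nM in this assay, at which 3 of the 3 values shown sit.

Compound 4 `CC1(C)CCC(NC/C=C/CN(C[C@H]2Cc3ccccc3CN2)[C@H]2CCCc3cccnc32)CC1` is the next member. Its change from compound 3 reads: 4,4-dimethylcyclohexyl in place of oxan-4-yl on an amine nitrogen. Among the measured compounds shown here, the steps that bear on it are the two that exchange the group on this amine nitrogen, a step that the two limits leave unreadable from compound 1 to compound 3 and a step that the two limits leave unreadable from compound 2 to compound 3; neither has a readable size. For the measured compounds named here, with three limits and no readable step, no direction can be set for this exchange in this assay, and the series so far has given no number at all in it.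

The expected step is a number no higher from compound 3 to compound 4 (the limit leaves the size open), that is, nothing beyond the scatter. Compound 4 is estimated at 30000 nM, with a range from 10000 nM to 100000 nM, and most likely the assay again reports only a limit for it.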

Compound 4, half-maximal effective concentration: > 30000 nM
Compound 4: only a limit was reported; the forecaster's own chance of this, stated with the estimate: 85%; the middle value sits exactly at the limit.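

In this assay compound 4 gives > 30000 nM, a limit of the assay and not a number. Among the compounds shown here, no step from compound 1, compound 2 or compound 3 to compound 4 can be read, each joining two limits. The compounds shown leave open whether any group on this amine nitrogen gives a measurable value, all resting at one point: the limit of > 30000 nM in this assay, at which 4 of the 4 values shown sit.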